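The source may hold more compounds than are shown below. What is called first, only, known or untested is meant among the compounds shown, and "the series" means these compounds.

Measured so far:
Compound 1, `CCC1(Cc2ccccc2)OS(=O)(=O)C=C1OCC(=O)OC`: in an ADME assay on HEL cells (Homo sapiens) for cytotoxicity, with a stated time of 3 days (on this read-out lower numbers stand for higher toxicity in this test and higher numbers for lower toxicity in this test), compound 1 gives > 400000 nM, which is a limit of the assay rather than a number.
Compound 2, `CCC1(Cc2ccccc2)OS(=O)(=O)C=C1OCc1ccc(OC)cc1`: in this assay compound 2 gives >= 200000 nM, also a limit.
Compound 3, `CCC1(Cc2ccccc2)OS(=O)(=O)C=C1OCc1ccc(Cl)c(Cl)c1`: in this assay compound 3 gives >= 20000 nM, again a limit.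

Compound 3 thus stands only at a limit, and the two other values shown are limits as well. The steps a step that the two limits leave unreadable from compound 1 to compound 3 and a step that the two limits leave unreadable from compound 2 to compound 3 therefore cannot be read in size. Compound 4, `CCC1(Cc2ccccc2)OS(=O)(=O)C=C1OCc1ccc(Br)cc1`, differs from compound 3 by 4-bromophenyl in place of 3,4-dichlorophenyl on a saturated chain carbon bound to an oxygen on an unsaturated carbon. For the measured compounds named here, no measured step with a readable size bears on this change, so no shift beyond the scatter is expected in this assay. Compound 4 is estimated at 40000 nM, within 10000 nM to 200000 nM, an expected step that the limit leaves unreadable from compound 3 to compound 4.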

Compound 4, minimum cytotoxic concentration: 80000 nM
Compound 4: middle estimate off by 2.0-fold (0.30 log units), on the low side; the range from low to high includes it.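

For the compounds shown here, compound 4 gives the first true number for a group on a saturated chain carbon bound to an oxygen on an unsaturated carbon in this assay. 4-Bromophenyl in place of methoxycarbonyl gives an at least 5.0-fold lower number from compound 1 to compound 4 (0.69 log units; beyond the scatter), and bromo in place of methoxy gives an at least 2.5-fold lower number from compound 2 to compound 4 (0.39 log units; beyond the scatter), so this change can raise toxicity in this test. The step involving 3,4-dichlorophenyl cannot be read, which leaves that group and 4-bromophenyl unordered.

Still open, as far as these compounds go, is whether a 4-fluorophenyl group or a chain carrying an amine at this place would move the number.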